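The compounds below may be only part of what the source reports. "The series", "measured", "known", "first", "only" and "open" are said of these compounds alone.

Measured so far:
- Compound 1 `COc1cccc2c1OCN(c1ccc3oc(-c4ccccc4)cc(=O)c3c1)C2` gives 54% in a functional assay on MCF7 cells (Homo sapiens) for inhibition, read by MTT assay, with a stated time of 48 h, tested at 15 ug/mL; a lower number here means less inhibition of growth, a higher number more inhibition of growth at the concentration tested
- Compound 2 `O=c1cc(-c2ccccc2)oc2ccc(N3COc4ccccc4C3)cc12` gives 34%
- Compound 3 `O=c1cc(-c2ccccc2)oc2ccc(N3COc4c(Br)cccc4C3)cc12` gives 37.8%

Compound 2 stands lowest of the three measured numbers. Compound 3 is within the scatter of it, so the two cannot be told apart, while compound 1 lies clearly above, as the step of a number 20 percentage points lower from compound 1 to compound 2 (beyond the scatter) shows.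

Compound 4 `Cc1ccc2c(c1)CN(c1ccc3oc(-c4ccccc4)cc(=O)c3c1)CO2` has not yet been measured. It differs from compound 2 in one place: methyl in place of hydrogen on an aromatic carbon.

Two measured steps speak to this change. The closest one is a number 3.8 percentage points higher from compound 2 to compound 3 (within the scatter), where a halogen entered the same kind of position and nothing moved beyond the scatter. The other two, a number 16.2 percentage points lower from compound 1 to compound 3 (beyond the scatter) and a number 20 percentage points lower from compound 1 to compound 2 (beyond the scatter), show that only the methoxy-bearing compound stands out. Among the measured compounds shown here, a methyl is a small group, like the bromo, and nothing among the measured compounds points to a large move in either direction. The expected step of a number 5 percentage points higher from compound 2 to compound 4 (within the scatter) is therefore small, within the scatter, and compound 4 is expected to give about 39%, with a likely range from 26% to 52%.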

Compound 4, percent growth inhibition at one concentration: 31%
The estimate for compound 4 lay 8 percentage points above the measured number; low and high end bracket the measured number.
By their numbers in this assay, from the lowest: compounds 4, 2 and 3 (each within the scatter of the next); then compound 1.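

In this assay, among the compounds shown here, the step of a number 3 percentage points lower from compound 2 to compound 4 (within the scatter) is the first reading at this position, an aromatic carbon that lies meta to a fused ring and para to a fused ring. Compound 2 and compound 4 cannot be told apart, so placing a methyl here, a single added carbon with no hydrogen-bond donor or acceptor, leaves growth inhibition at the tested concentration unchanged within the scatter, neither gaining nor clearly losing any. No measurement in hand explains why this change leaves the number where it stands.

One small carbon group at one carbon gives only a narrow view, so the compounds shown leave open whether a larger or different group here, such as a methoxy, an amine, a carboxylic acid or a longer chain like butyl, would shift the number beyond the scatter. They also leave open whether the same methyl would read the same way on the other carbons of this ring, since only this single placement of it appears.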